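The source may hold more compounds than are shown below. What is called first, only, known or untested is meant among the compounds shown, and "the series" means these compounds.

Measured so far in a functional assay on DU-145 cells (Homo sapiens) for inhibition, read by trypan blue exclusion, with a stated time of 96 h; a higher number here means a weaker inhibitor of growth, a lower number a stronger inhibitor of growth:
compound 1, `O=C(/C(=C\c1ccc([N+](=O)[O-])c(O)c1)SCc1ccc(Br)cc1)c1ccc([N+](=O)[O-])cc1`, gives 1000 nM
compound 2, `O=C(/C(=C\c1ccc(O)c([N+](=O)[O-])c1)SCc1ccc(Br)cc1)c1ccc([N+](=O)[O-])cc1`, gives 10000 nM
compound 3, `O=C(/C(=C\c1ccc([N+](=O)[O-])c(O)c1)Sc1ccc(Br)cc1)c1c(F)c(F)c(F)c(F)c1F`, gives 1000 nM

Compound 1 and compound 2 share a core and differ in a single ring: 4-hydroxy-3-nitrophenyl in place of 3-hydroxy-4-nitrophenyl on a double-bonded chain carbon bound to a double-bonded chain carbon. This change gave a 10-fold higher number from compound 1 to compound 2 (1.00 log units; beyond the scatter), a clear weakening of growth inhibition. Compound 3 is built on another core; how that core differs from the core of compound 1 is not broken down here. In this assay compound 3 stands level with compound 1 at the digits given, and these two together hold the lowest numbers among the three measured compounds.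

Compound 4, `O=C(/C(=C\c1ccc(O)c([N+](=O)[O-])c1)Sc1ccc(Br)cc1)c1c(F)c(F)c(F)c(F)c1F`, is not yet measured. It relates to compound 3 as compound 2 relates to compound 1: 4-hydroxy-3-nitrophenyl in place of 3-hydroxy-4-nitrophenyl on a double-bonded chain carbon bound to a double-bonded chain carbon. The change is the same one, at the same place, so there is one prior instance to go on. The expectation for compound 4 rests on that single instance, because a 10-fold higher number from compound 1 to compound 2 (1.00 log units; beyond the scatter) is the only measured outcome of this change. For compound 4 in this assay a step of about an 8.0-fold higher number from compound 3 to compound 4 (0.90 log units; beyond the scatter) is expected. Compound 4 is accordingly estimated at 8000 nM, with a range from 2500 nM to 25000 nM.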

Compound 4, concentration for 50% growth inhibition: 1000 nM
Beside the measured number, compound 4's estimate is 8.0-fold (0.90 log units) above it; the whole stated range lies above it.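

In this assay, 4-hydroxy-3-nitrophenyl in place of 3-hydroxy-4-nitrophenyl gives no change at the digits printed from compound 3 to compound 4 (within the scatter), so the loss of growth inhibition seen on the core of compound 1 does not appear on the core of compound 3. The change therefore cannot be carried from one core to the other in this series with a fixed size of effect: the same change on two cores in this assay, a 10-fold higher number (1.00 log units; beyond the scatter) from compound 1 to compound 2 and no change at the digits printed (within the scatter) from compound 3 to compound 4, 10-fold (1.00 log units) apart, beyond the scatter of two such steps. This shows that the outcome of the change depends on the core in this one pair, but two cores are too few for a general rule, and since they differ in more than one place, the data do not show which part of the core decides the outcome.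

Open, going by these compounds, is how the same change behaves on a core that differs from that of compound 1 in one place only. Also open, on these data alone, is what an amine in place of the hydroxyl group, or a carboxylic acid in place of the nitro group, would do on either core.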